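The compounds below may be only part of what the source reports. "The series", "measured", "known", "first", "only" and "open" are said of these compounds alone.

Compound 1 `Cc1ccc(S(=O)(=O)N2CC(c3nc(-c4cccc(Cl)c4)no3)C2)cc1` — in an assay on HEK293 cells for positive allosteric modulation of metabotropic glutamate receptor 5 (Homo sapiens), read by FLIPR (on this read-out higher numbers stand for an effect only at larger amounts of compound and lower numbers for an effect already at smaller amounts), compound 1 gives > 10000 nM, which is a limit of the assay and not a number.
Compound 2 `O=C(C1CCC1)N1CC(c2nc(-c3cccc(Cl)c3)no2)C1` — in this assay compound 2 gives > 10000 nM, again a limit of the assay.
Compound 3 `O=C(C1CCC(C(F)(F)F)CC1)N1CC(c2nc(-c3cccc(F)c3)no2)C1` — in this assay compound 3 gives 680 nM.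

Of the three measured compounds, only compound 3 returns a number in this assay. Compound 1 cannot be placed relative to compound 2, because both sit at the limit of > 10000 nM in this assay, at which 2 of the 3 values shown sit, and the two share the same standing: an effect, if any, only at amounts beyond what the assay reaches. Compound 3, with its measured value, stands apart from that limit.

Compound 4 `O=S(=O)(c1ccc(Cl)cc1)N1CC(c2nc(-c3cccc(Cl)c3)no2)C1` is built from compound 1 by one change: chloro in place of methyl on an aromatic carbon. Among the compounds with values here, no pair of measured compounds shows this change, so nothing measured here tells how large a step it brings in this assay. Given how small the change is, the expectation is a step of none beyond the scatter, in either direction, and compound 4 is expected to remain near the limit where compound 1 sits.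

For compound 4 the expected value in this assay is 12000 nM, with a range from 3000 nM to 50000 nM.

The estimate means a step that the limit leaves unreadable from compound 1 to compound 4, which is expected to stay within the usual scatter, with a real chance that only a limit is reported again.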

Compound 4, half-maximal effective concentration: > 10000 nM
Compound 4 was reported as a limit (the forecaster's own chance of this, stated with the estimate: 70%); the middle value is on the limit's open side.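

Compound 1 and compound 4 both return only a limit in this assay, so no step can be read between them, because neither value is a number: the limit of > 10000 nM in this assay, at which 3 of the 4 values shown sit.

The compounds shown leave open whether 4-methylphenyl and 4-chlorophenyl differ at all in this assay, and how far beyond the limit either compound lies.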